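The source may hold more compounds than are shown below. What is called first, only, known or untested is meant among the compounds shown, and "the series" means these compounds.

Compound 1 `COc1ccc(N2C(=O)COc3ccc(-c4cnc5ccccc5c4)cc32)cc1` carries a methoxy group on the ring attached to the nitrogen of the shared core. In a functional assay on HepG2 cells (Homo sapiens) for antiproliferative activity, read by MTT assay, with a stated time of 72 h (a lower number here means a stronger inhibitor, a higher number a weaker inhibitor), compound 1 gives > 40000 nM, which is a limit of the assay rather than a measured number. Two companions with the same core were tested beside it. Compound 2 `COc1ncc(-c2ccc3c(c2)N(C2CC2)C(=O)CO3)cc1NS(=O)(=O)c1ccc(F)cc1` gives 14400 nM in this assay. Compound 3 `Cc1ccc(N2C(=O)COc3ccc(-c4cccc(NS(=O)(=O)c5ccc(F)cc5)c4)cc32)cc1` gives > 40000 nM in this assay, again a limit of the assay. Compound 1 thus stands at the limit of > 40000 nM in this assay, at which 2 of the 3 values shown sit, with no true number of its own.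

Compound 4 `O=C1COc2ccc(-c3cnc4ccccc4c3)cc2N1c1ccc(F)cc1` has not been measured. Its change from compound 1 is fluoro in place of methoxy on an aromatic carbon. Within the data shown here, no pair of measured compounds shows this change on its own, so its effect is open. Because compound 1 rests at the limit of > 40000 nM in this assay, at which 2 of the 3 values shown sit, any shift in this assay is expected to be small, in no clear direction, and most likely compound 4 will also return only a limit. Compound 4 is therefore expected to give about 50000 nM, with a range from 15000 nM to 200000 nM, an estimated step that the limit leaves unreadable from compound 1 to compound 4.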

Compound 4, half-maximal inhibitory concentration: 37200 nM
Estimate against measurement, compound 4: 1.3-fold (0.13 log units) above, within the range that was stated.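

With fluoro in place of methoxy, para to a large group, the shared core gives a true number instead of a limit, and compound 4 reads 37200 nM in this assay. From the compounds shown here alone, compound 1 has only a limit of the assay and no number of its own: the limit of > 40000 nM in this assay, at which 2 of the 4 values shown sit. The change can therefore be read only as a floor, an at least 1.0-fold lower number from compound 1 to compound 4 (0.03 log units; that floor lies within the scatter), so its true size is unknown and a real shift cannot be told apart from ordinary scatter.

The compounds shown leave open how large the step truly is, and whether any group at this position can give a clearly stronger result. How an amine, a carboxylic acid or a longer chain at this place would read in this assay also remains an open question.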